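Compound 2 to compound 4: chloro in place of nitro

The source may report more compounds than this note shows. Statements on the series, on what has been measured and on what is new or still open speak of the compounds shown alone.

In an ADME assay on J774.A1 cells (Mus musculus) for cytotoxicity, read by MTT assay, with a stated time of 48 h (on this read-out higher numbers stand for lower toxicity in this test and lower numbers for higher toxicity in this test), compound 2 `COc1ccc(CNC(=O)c2c([N+](=O)[O-])noc2-c2ccc([N+](=O)[O-])cc2)cc1` gives 69600 nM. Going by the values given here, this is the only number available for the series, so compound 2 can be neither ranked against its neighbours nor placed high or low within a range. Compound 1 `O=C(NCc1ccc(F)cc1)c1c([N+](=O)[O-])noc1-c1ccc([N+](=O)[O-])cc1` offers no comparison, its entry reading "not determined" (no result reported). Compound 3 `O=C(NCc1cccc(Cl)c1Cl)c1c([N+](=O)[O-])noc1-c1ccc([N+](=O)[O-])cc1` is in the same position, with "not determined" (no result reported). Both share the 4-nitrophenyl group with compound 2, but neither shows what that group contributes to the read-out.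

Compound 4 `COc1ccc(CNC(=O)c2c([N+](=O)[O-])noc2-c2ccc(Cl)cc2)cc1` is the next to be measured in this assay. It keeps the amide side of compound 2 and the shared core, and it carries chloro in place of nitro on an aromatic carbon, para to a large group, a change from 4-nitrophenyl to 4-chlorophenyl: chloro in place of nitro on an aromatic carbon.

Among the compounds with values here, no measured pair gives a size for any step, so the expectation is a weak one. It is anchored only on compound 2 at 69600 nM. The expected change is a 1.2-fold lower number from compound 2 to compound 4 (0.06 log units; within the scatter), which is estimated to lie within the scatter, with no direction favoured. For compound 4 the estimated value is 60000 nM, with an expected range from 20000 nM to 180000 nM.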

Compound 4, half-maximal cytotoxic concentration: 89500 nM
Estimate against measurement, compound 4: 1.5-fold (0.17 log units) below, and the stated range covers the measured number.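

In this assay, the series now has its first readable step, a 1.3-fold higher number from compound 2 to compound 4 (0.11 log units; within the scatter), and it lies within the scatter, so compound 2 and compound 4 cannot be told apart in this test. At this position, on an aromatic carbon para to a large group, the 4-nitrophenyl group is therefore not needed for a number of this size: the 4-chlorophenyl group, with one chlorine atom in place of the larger nitro and without its hydrogen-bond acceptors, reads the same within the scatter. No measurement shown gives any reason for this result.

Going by these compounds, whether this tolerance extends to a different kind of group at the same position, such as an amine or a carboxylic acid, remains open, since one step covers only chloro in place of nitro with a single amide side. The amide side itself cannot be read yet, as compound 1 and compound 3 offer no number, and the compounds shown also leave open how an amine in place of the nitro on the shared core would read.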